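Nitro in Place of Chloro: Expected Cell Tolerance

The compounds below may be only part of what the source reports. "The series", "measured", "known", "first", "only" and "open" are said of these compounds alone.

Compound 1 `c1ccc(-c2noc(Cc3c[nH]c4ccccc34)n2)cc1` and compound 2 `Clc1ccc(-c2noc(Cc3c[nH]c4ccccc34)n2)cc1` share one core. In an ADME assay on cells (Splenocyte, Mus musculus, strain BALB/c) for cytotoxicity, read by CCK-8 assay, with a stated time of 48 h (a higher number here means that more compound is tolerated, a lower number that less compound is tolerated), compound 1 gives > 50000 nM, which is a limit of the assay rather than a number. In this assay compound 2 gives 42800 nM. Compound 2 therefore stands as the only number shown; the other value is the limit of > 50000 nM in this assay, at which 1 of the 2 values shown sits. Going by the values given here, the single measured step, an at least 1.1-fold lower number from compound 1 to compound 2 (0.06 log units; that floor lies within the scatter), lies within the scatter. Compound 3 `O=[N+]([O-])c1ccc(-c2noc(Cc3c[nH]c4ccccc34)n2)cc1` differs from compound 2 by nitro in place of chloro on an aromatic carbon. Since that one step was small, no change beyond the scatter is expected in this assay. Compound 3 is estimated at 40000 nM, between 15000 nM and 80000 nM, an expected step of a 1.1-fold lower number from compound 2 to compound 3 (0.03 log units; within the scatter).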

Compound 3, half-maximal cytotoxic concentration: > 50000 nM
Compound 3 gave a limit, no number (the forecaster's own chance of this, stated with the estimate: 35%); middle value at least 1.2-fold (0.09 log units) away from the limit.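

At this place, para to a large group, nitro in place of chloro gives an at least 1.1-fold higher number from compound 2 to compound 3 (0.06 log units; that floor lies within the scatter) in this assay. Compound 3 gives a limit, not a number, and the step from compound 1 to compound 3 cannot be read. Neither chloro nor nitro on this aromatic carbon has yet produced a step shown to lie beyond the scatter: the limit of > 50000 nM in this assay, at which 2 of the 3 values shown sit.

From the compounds shown here alone, whether an amine or a carboxylic acid at this place would give a step beyond the scatter remains open. Going by these compounds, how far compound 1 and compound 3 lie from their limits also remains open.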